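Ethyl to isopropyl: the step to compound 4

The compounds below may be only part of what the source reports. "The series", "measured", "known", "first", "only" and "open" are said of these compounds alone.

In a functional assay on K562 cells (Homo sapiens) for inhibition, read by MTT assay, with a stated time of 72 h (a higher number here means a weaker inhibitor, a lower number a stronger inhibitor), compound 1 (`Cc1ccc(C(=O)/C=C/C(=O)O)cc1C`) gives 5620 nM and compound 2 (`O=C(O)/C=C/C(=O)C1CCc2ccccc2C1`) gives 5600 nM. Compound 3 (`CCc1ccc(C(C)C)cc1C(=O)/C=C/C(=O)O`) gives 1360 nM, the lowest of the three numbers and beyond the scatter from both of the others. Compound 4 (`CC(C)c1ccc(C(C)C)c(C(=O)/C=C/C(=O)O)c1`) has not yet been measured. It differs from compound 3 by methyl in place of hydrogen on a saturated chain carbon bound to an aromatic carbon and a saturated chain carbon, which turns ethyl into isopropyl. Going by the values given here, no two measured compounds differ in one place, so the series offers no direct precedent for this change. The expectation therefore rests on compound 3 at 1360 nM and on the single added carbon. A step within the scatter is expected in this assay, with no firm direction. The estimated step is a 1.1-fold lower number from compound 3 to compound 4 (0.05 log units; within the scatter). For compound 4 the estimate is 1200 nM, with an expected range of 600 nM to 2500 nM.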

Compound 4, half-maximal inhibitory concentration: 3280 nM
Compound 4: middle estimate off by 2.7-fold (0.44 log units), on the low side; the measured number lies above the stated range.
By their numbers in this assay, from the lowest: compound 3; then compounds 4, 2 and 1 (each within the scatter of the next).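

The change from ethyl to isopropyl gives the series its first step that can be read at a single place. In this assay the step is a 2.4-fold higher number from compound 3 to compound 4 (0.38 log units; beyond the scatter) and points toward a weaker inhibitor, so one added methyl on this saturated chain carbon bound to an aromatic carbon and a saturated chain carbon moves the number beyond the scatter. The earlier compounds, with no pair differing in one place, could show neither the direction nor the size of any such change, and no measurement here bears on the reason for this step.

From the compounds shown here alone, what a longer chain such as propyl, or a hydroxyl group, would do at this same carbon remains open. A single step also leaves open whether the same added methyl would move the number in the same direction on another core.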